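Removing a Nitrile from a Weak Transporter Inhibitor

The source may hold more compounds than are shown below. What is called first, only, known or untested is meant among the compounds shown, and "the series" means these compounds.

Compound 1 `CNCc1ccccc1Oc1ccc(Cl)cc1F`: in an assay on HEK293 cells for inhibition of sodium-dependent dopamine transporter (Homo sapiens) (on this read-out lower numbers stand for stronger inhibition and higher numbers for weaker inhibition), compound 1 gives "not determined" (no result reported).
Compound 2 `CNCc1cc(C#N)ccc1Oc1ccc(Cl)cc1OC`: in this assay compound 2 gives > 40000 nM, which is a limit of the assay and not a number.

Compound 2 therefore stands only at the limit of > 40000 nM in this assay, at which 1 of the 2 values shown sits; no single number is known for it, and compound 1 has no result at all. Compound 3 `CNCc1ccccc1Oc1ccc(Cl)cc1OC` is the next compound to be measured. Compared with compound 2, it carries hydrogen in place of cyano on an aromatic carbon, that is, hydrogen in place of cyano on an aromatic carbon. For the measured compounds named here, no measured step between two compounds of this small set is available, so the size of such a change cannot be read from the data. Starting from the limit (the limit of > 40000 nM in this assay, at which 1 of the 2 values shown sits), the step of an at least 1.3-fold lower number from compound 2 to compound 3 (0.12 log units; that floor lies within the scatter) is expected to be small, in either direction, and not clearly beyond the scatter. For compound 3 the estimate in this assay is 30000 nM, with a range from 5000 nM to 150000 nM.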

Compound 3, half-maximal inhibitory concentration: 19600 nM
Beside the measured number, compound 3's estimate is 1.5-fold (0.18 log units) above it; low and high end bracket the measured number.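

For the compounds shown here, compound 3 gives the first single number in this set for this assay, so the hydrogen-bearing side of this change now has a measured value. Replacing the nitrile with hydrogen on this aromatic carbon gives an at least 2.0-fold lower number from compound 2 to compound 3 (0.30 log units; that floor lies within the scatter), so the data do not establish a real difference beyond ordinary assay variation. Compound 2 is known only as a limit of the assay, and the true size of the step remains unknown because that end of it is not a number: the limit of > 40000 nM in this assay, at which 1 of the 3 values shown sits.

The compounds shown leave open how other groups at this aromatic carbon, such as an amine or a carboxylic acid, would affect the read-out. They also leave open whether removing the nitrile has the same effect on a different core.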